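Changing One Ring Substituent on the Shared Core

The compounds below may be only part of what the source reports. "The series", "measured", "known", "first", "only" and "open" are said of these compounds alone.

In an ADME assay on microsomes from liver (Rattus norvegicus), read by LC-MS, with a stated time of 60 min, tested at 1 uM (a higher number here means that the liver removes a larger share of the compound in one pass, a lower number that the liver removes a smaller share), compound 3 `O=C1CN(c2nccn3c(-c4ccc5c(c4)CC(=O)N5)c(-c4ccc(F)cc4)nc23)CCN1` gives 0.7. Compound 2 `O=C1Cc2cc(-c3c(-c4ccc(F)cc4)nc4c(N5CCC(F)CC5)nccn34)ccc2N1` is level with it at 0.7, and these two together stand highest of the three measured numbers; compound 1 `O=C1Cc2cc(-c3c(-c4ccc(F)cc4)nc4c(N5CCC(O)CC5)nccn34)ccc2N1` stands furthest from them, at 0.4. Compound 4 `CC(=O)N1CCN(c2nccn3c(-c4ccc5c(c4)CC(=O)N5)c(-c4ccc(F)cc4)nc23)CC1` differs from compound 3 in one place: 4-acetylpiperazin-1-yl in place of 3-oxopiperazin-1-yl on an aromatic carbon. Within the data shown here, two measured steps bear on this change. The step a number 0.30 higher from compound 1 to compound 3 (beyond the scatter) was modest but beyond the scatter, while no change at the digits printed from compound 2 to compound 3 (within the scatter) stayed within the scatter. Because compound 3 already sits at 0.7, and the replacement again removes a hydrogen-bond donor, only a small further rise is expected. Compound 4 is therefore estimated at 0.75, with a range from 0.6 to 0.9, which means an expected step of a number 0.050 higher from compound 3 to compound 4 (within the scatter).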

Compound 4, hepatic extraction ratio: 0.5
Estimate against measurement, compound 4: 0.25 above; the measured number lies below the stated range.
By their numbers in this assay, from the lowest: compounds 1 and 4 (each within the scatter of the next); then compounds 2 and 3 (each within the scatter of the next).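

In this assay the step to 4-acetylpiperazin-1-yl, which enters with 0 hydrogen-bond donors, gives a number 0.20 lower from compound 3 to compound 4 (beyond the scatter), so losing the amide hydrogen at this position does not by itself raise the number. The same group gives a number 0.20 lower from compound 2 to compound 4 (beyond the scatter) and also a number 0.10 higher from compound 1 to compound 4 (within the scatter), which shows that this position can move the number even between two closely related groups that each hold a ring carbonyl or acetyl carbonyl. No measured evidence explains this result. Open, from the compounds shown here alone, is where a free amine on the same ring, or a longer acyl chain in place of acetyl, would fall relative to compound 3 and compound 4.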